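Series notes: bromo in place of fluoro on the shared core

The compounds below may be only part of what the source reports. "The series", "measured", "known", "first", "only" and "open" are said of these compounds alone.

Measured in an assay on brain for binding affinity to Neuronal acetylcholine receptor; alpha4/beta2 (Rattus norvegicus), read by radioligand binding; a higher number here means a weaker inhibitor, a lower number a stronger inhibitor: compound 1 `CCc1ccc(OC[C@@H]2CCN2)cn1` gives 19 nM; compound 2 `N#Cc1ccc(OC[C@@H]2CCN2)cn1` gives 1.9 nM; compound 3 `Fc1cncc(OC[C@@H]2CCN2)c1` gives 0.076 nM.

Compound 3 holds the lowest number of the three; compound 2 is the nearest with its higher value, and compound 1 lies furthest away. Compound 4 `Brc1cncc(OC[C@@H]2CCN2)c1` differs from compound 3 by bromo in place of fluoro on an aromatic carbon. Within the data shown here, the only single-point step measured so far, a 10-fold lower number from compound 1 to compound 2 (1.00 log units; beyond the scatter), exchanges groups at another carbon of the core and says little about swapping one halogen for another. Among the measured compounds shown here, no measured step joins compound 3 to any other halogen variant. The change is therefore expected to move this assay only slightly, a 1.3-fold higher number from compound 3 to compound 4 (0.12 log units; within the scatter), a step inside the scatter. Compound 4 is estimated at 0.1 nM with a range of 0.03 nM to 0.4 nM.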

Compound 4, inhibition constant: 0.18 nM
For compound 4 the middle estimate is 1.8-fold (0.26 log units) below the measured one, within the range that was stated.
By their numbers in this assay, from the lowest: compound 3; then compound 4; then compound 2; then compound 1.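

Bromo in place of fluoro gives a 2.4-fold higher number from compound 3 to compound 4 (0.37 log units; beyond the scatter) in this assay and so marks a modest change that stands beyond the usual scatter. This position on the shared core therefore responds to which halogen it carries, and fluoro holds the lower number of the pair. Nothing measured here accounts for this difference.

Going by these compounds, whether chloro would fall between these two halogens remains open. Also open, on these data alone, is how a non-halogen group, such as an amine or a carboxylic acid, would read at this position.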